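The compounds below may be only part of what the source reports. "The series", "measured", "known", "first", "only" and "open" are said of these compounds alone.

Compound 3 `CNC(=O)[C@@]12C[C@@H]1[C@@H](n1cnc3c(NC)nc(C#Cc4cc5ccccc5o4)nc31)[C@H](O)[C@@H]2O` carries 1-benzofuran-2-yl on the triple-bonded carbon. In an assay on CHO cells for displacement of a labelled ligand from adenosine receptor A1 (Homo sapiens), read by scintillation counting, with a stated time of 60 min, tested at 10 uM (on this read-out lower numbers stand for less inhibition and higher numbers for more inhibition at the one concentration tested (going by the name of the read-out)), compound 3 gives 13% and stands lowest of the three numbers shown, though each gap to the others is within the scatter. Compound 1 `CNC(=O)[C@@]12C[C@@H]1[C@@H](n1cnc3c(NC)nc(C#Cc4ccccc4)nc31)[C@H](O)[C@@H]2O` gives 18% and compound 2 `CNC(=O)[C@@]12C[C@@H]1[C@@H](n1cnc3c(NC)nc(C#Cc4cccc(F)c4)nc31)[C@H](O)[C@@H]2O` gives 14%. The move a number 5 percentage points lower from compound 1 to compound 3 (within the scatter) and the move a number 1 percentage points lower from compound 2 to compound 3 (within the scatter) both exchange the aryl on the triple-bonded carbon and both sit within the scatter; the move a number 4 percentage points lower from compound 1 to compound 2 (within the scatter), fluoro in place of hydrogen on an aromatic carbon, likewise stays within the scatter.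

Compound 4 `CNC(=O)[C@@]12C[C@@H]1[C@@H](n1cnc3c(NC)nc(C#Cc4ccsc4)nc31)[C@H](O)[C@@H]2O` is not yet measured. Its difference from compound 3 is thiophen-3-yl in place of 1-benzofuran-2-yl on a triple-bonded carbon, so one five-membered aromatic ring with 1 hetero atom enters where two rings leave, on the same triple-bonded carbon. Every exchange of the aryl on this carbon seen so far has stayed within the scatter, so no step beyond the scatter is expected in this assay. For compound 4 the expected step is a number 1 percentage points higher from compound 3 to compound 4 (within the scatter). Compound 4 is estimated at 14%, with a range from 4% to 24%.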

Compound 4, a percentage reported as inhibition, at one concentration (the size of the read-out at that concentration, not a potency): 11%
Compound 4: the middle estimate sits 3 percentage points above what was measured; the range from low to high includes it.
By their numbers in this assay, from the lowest: compounds 4, 3, 2 and 1 (each within the scatter of the next).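

In this assay, the aryl on the triple-bonded carbon can now lose a whole ring and exchange oxygen for sulfur, thiophen-3-yl with 5 heavy atoms replacing 1-benzofuran-2-yl with 9, and the outcome is still a number 2 percentage points lower from compound 3 to compound 4 (within the scatter). The same group set against the carbon-only aryls gives a number 3 percentage points lower from compound 2 to compound 4 (within the scatter) and a number 7 percentage points lower from compound 1 to compound 4 (within the scatter), so across these four aromatic groups neither ring count nor hetero atom separates the numbers. Nothing available bears on why the numbers stay this close.

All four groups on the triple-bonded carbon are aromatic rings, which leaves open whether a cyclohexyl ring, a longer alkyl chain, or a chain ending in an amine or a carboxylic acid would also stay within the scatter.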